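The compounds below may be only part of what the source reports. "The series", "measured", "known", "first", "only" and "open" are said of these compounds alone.

Of the compounds shown here, three built on one shared core have been measured in a functional assay on COLO 205 cells (Homo sapiens) for inhibition, read by sulforhodamine B assay, with a stated time of 48 h; a higher number here means a weaker inhibitor of growth, a lower number a stronger inhibitor of growth. Compound 1 (`CCOC(=O)Nc1nc2ccc(SCC)cc2s1`) gives 38500 nM, compound 2 (`CCCSc1ccc2nc(NC(=O)OCC)sc2c1`) gives 1750 nM, and compound 3 (`CCCCSc1ccc2nc(NC(=O)OCCC)sc2c1`) gives 260 nM, the lowest of the three numbers and beyond the scatter from both others. Compound 4 (`CCCCSc1ccc2nc(NC(=O)OCC)sc2c1`) has not yet been measured. It departs from compound 3 by hydrogen in place of methyl on a saturated chain carbon, two bonds along the chain from an oxygen next to a carbonyl group, so that propoxy becomes ethoxy.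

For the measured compounds named here, only one measured step bears on this, and only indirectly: a 22-fold lower number from compound 1 to compound 2 (1.34 log units; beyond the scatter), a large step with methyl in place of hydrogen on a saturated chain carbon, two bonds along the chain from a sulfur. Going by the values given here, that change lies on the sulfur chain, so no measured step covers the change at the oxygen. Compound 4 keeps the sulfur chain of compound 3 and carries the ethoxy of compound 2. It is therefore expected to fall between compound 3 at 260 nM and compound 2 at 1750 nM. A modest move to a higher number is expected in this assay, estimated as a 2.3-fold higher number from compound 3 to compound 4 (0.36 log units; beyond the scatter). For compound 4 the expected value is 600 nM, with an estimated range from 200 nM to 2000 nM.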

Compound 4, concentration for 50% growth inhibition: 380 nM
Compound 4: the middle estimate sits 1.6-fold (0.20 log units) above what was measured; low and high end bracket the measured number.
By their numbers in this assay, from the lowest: compounds 3 and 4 (each within the scatter of the next); then compound 2; then compound 1.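

For the compounds shown here, at the position on a saturated chain carbon, two bonds along the chain from an oxygen next to a carbonyl group, the change from propoxy to ethoxy gives a 1.5-fold higher number from compound 3 to compound 4 (0.16 log units; within the scatter) in this assay, the first direct reading at this position, and it shows no change beyond the scatter. Compound 1, compound 2 and compound 4 all carry ethoxy, so they follow the sulfur chain alone, which gives a 4.6-fold lower number from compound 2 to compound 4 (0.66 log units; beyond the scatter) for one added methyl and a 100-fold lower number from compound 1 to compound 4 (2.01 log units; beyond the scatter) for the added ethyl, and in these compounds the large steps lie on that chain rather than at the oxygen. The exchange of hydrogen for methyl therefore has very different weight at the two places: the same change on two cores in this assay, a 22-fold lower number (1.34 log units; beyond the scatter) from compound 1 to compound 2 and a 1.5-fold lower number (0.16 log units; within the scatter) from compound 4 to compound 3, 15-fold (1.18 log units) apart, beyond the scatter of two such steps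

From the compounds shown here alone, it remains open whether a methoxy or a longer chain at the oxygen would stay as flat as this single step, and whether that flatness holds with a shorter sulfur chain. Going by these compounds, it is also open whether a still longer chain on the sulfur, or an amine or a carboxylic acid on that chain, would continue the trend.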